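Trifluoromethoxy in Place of Trifluoromethyl on a Second Core

The source may report more compounds than this note shows. Statements on the series, on what has been measured and on what is new or still open speak of the compounds shown alone.

Compound 1 `CC(O)(CSc1ccc(C(F)(F)F)cc1)C(=O)Nc1cccc(S(F)(F)(F)(F)F)c1` and compound 2 `CC(O)(CSc1ccc(OC(F)(F)F)cc1)C(=O)Nc1cccc(S(F)(F)(F)(F)F)c1` share one core, while compound 3 `CC(O)(COc1cccc(C(F)(F)F)c1)C(=O)Nc1cccc(S(F)(F)(F)(F)F)c1` and compound 4 `CC(O)(COc1cccc(OC(F)(F)F)c1)C(=O)Nc1cccc(S(F)(F)(F)(F)F)c1` share another; the difference between the two cores is not broken down here. In a functional assay on DU-145 cells (Homo sapiens) for antiproliferative activity, read by propidium iodide staining, with a stated time of 96 h (on this read-out higher numbers stand for weaker inhibition and lower numbers for stronger inhibition), compound 1 gives 27200 nM, and compound 2 gives 24700 nM. The change between them, (trifluoromethoxy in place of trifluoromethyl on an aromatic carbon), made a step of a 1.1-fold lower number from compound 1 to compound 2 (0.04 log units; within the scatter). In this assay compound 3 gives 31700 nM, a number lying within the scatter of both compound 1 and compound 2. Compound 4 carries the same kind of change relative to compound 3, (trifluoromethoxy in place of trifluoromethyl on an aromatic carbon), though the place is not identical: para to a large group in the first pair, meta to a large group in the second. Beside the earlier step, the step in this assay is expected to be a 1.1-fold lower number from compound 3 to compound 4 (0.04 log units; within the scatter), an expectation that rests on compound 3 at 31700 nM together with the step of a 1.1-fold lower number from compound 1 to compound 2 (0.04 log units; within the scatter). Compound 4 is accordingly estimated at 29000 nM, with an expected range from 15000 nM to 60000 nM.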

Compound 4, half-maximal inhibitory concentration: 30100 nM
Beside the measured number, compound 4's estimate is 1.0-fold (0.02 log units) below it; the range from low to high includes it.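

In this assay, trifluoromethoxy in place of trifluoromethyl on the second core gives a 1.1-fold lower number from compound 3 to compound 4 (0.02 log units; within the scatter). Set beside the step on the first core, the two agree: the same change on two cores in this assay, a 1.1-fold lower number (0.04 log units; within the scatter) from compound 1 to compound 2 and a 1.1-fold lower number (0.02 log units; within the scatter) from compound 3 to compound 4, 1.0-fold (0.02 log units) apart, within the scatter of two such steps This shows only that the change left the number within the scatter on both cores; it does not show that a step of real size would carry over, since neither pair contains one, and two pairs are too few to support a rule for the series. Nor can the core be separated from the place of the change, as the two differ together between the pairs.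

The compounds shown leave open whether a group of another kind on this aromatic carbon, such as an amine, a nitrile or a carboxylic acid, would move the number beyond the scatter. They also leave open whether the agreement would hold on a core in which the pentafluorosulfanyl group gives way to another group.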